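Replacing the 2-methoxypropyl group of compound 2

The compounds below may be only part of what the source reports. "The series", "measured", "known", "first", "only" and "open" are said of these compounds alone.

Measured in a functional assay on DU-145 cells (Homo sapiens) for cytotoxicity, read by MTT assay; a higher number here means a weaker inhibitor, a lower number a stronger inhibitor:
- compound 1 `CC(C)=CC[C@@H](OC[C@H](C)O)C1=CC(=O)c2c(O)ccc(O)c2C1=O`: 24500 nM
- compound 2 `COC(C)CO[C@H](CC=C(C)C)C1=CC(=O)c2c(O)ccc(O)c2C1=O`: 16600 nM
- compound 3 `COCCO[C@H](CC=C(C)C)C1=CC(=O)c2c(O)ccc(O)c2C1=O`: 43200 nM

Compound 2, at 16600 nM, cannot be separated from its nearest neighbour, as the data show a 1.5-fold lower number from compound 1 to compound 2 (0.17 log units; within the scatter). It is separated from the remaining compound, with a 2.6-fold higher number from compound 2 to compound 3 (0.42 log units; beyond the scatter).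

The next compound to be tested is compound 4 `CC[C@](C)(O)CC(=O)O[C@H](CC=C(C)C)C1=CC(=O)c2c(O)ccc(O)c2C1=O`, and its change from compound 2 is (2-hydroxy-2-methylbutyl)carbonyl in place of 2-methoxypropyl on an oxygen on a saturated carbon. The same difference, cut one bond further out, reads 2-methoxypropoxy to ((2-hydroxy-2-methylbutyl)carbonyl)oxy.

All three measured steps alter this same side chain, so they bear on the change, but only indirectly. Besides the two above, the series shows a 1.8-fold higher number from compound 1 to compound 3 (0.25 log units; within the scatter). Going by the values given here, none of the measured compounds carries a carbonyl in this chain, so no measured step sizes the exchange directly. The steps therefore serve only as a scale, and the largest of them is modest. A small move toward a lower number is expected, without a clear passage beyond the scatter. The expected step is a 1.5-fold lower number from compound 2 to compound 4 (0.18 log units; within the scatter). The exchange is larger than any measured one. The range is kept wide. Compound 4 is estimated at 11000 nM, with an expected range from 3500 nM to 35000 nM.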

Compound 4, half-maximal inhibitory concentration: 20500 nM
The estimate for compound 4 lay 1.9-fold (0.27 log units) below the measured number; the range from low to high includes it.
By their numbers in this assay, from the lowest: compounds 2, 4, 1 and 3 (each within the scatter of the next, the first and the last beyond it).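

In this assay the oxygen on a saturated carbon carries a carbonyl-linked chain without a clear shift, since (2-hydroxy-2-methylbutyl)carbonyl in place of 2-methoxypropyl gives a 1.2-fold higher number from compound 2 to compound 4 (0.09 log units; within the scatter) and the same group in place of 2-hydroxypropyl gives a 1.2-fold lower number from compound 1 to compound 4 (0.08 log units; within the scatter) so that compound 4 cannot be separated from compound 1 or compound 2. In place of 2-methoxyethyl the same group gives a 2.1-fold lower number from compound 3 to compound 4 (0.32 log units; beyond the scatter) and thus places compound 4 with compound 2 as separated from compound 3, a separation that compound 1 does not share. The entering group has 8 heavy atoms against the 5 of 2-methoxypropyl and adds a hydrogen-bond donor, yet compound 4 stays inside the span already set by compound 2 and compound 3.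

Nothing available explains why these different side chains give such similar numbers. As far as these compounds go, whether an amine, a carboxylic acid or a longer chain on this oxygen would move the number clearly beyond the scatter remains open, as does the contribution of the defined stereocentre in the (2-hydroxy-2-methylbutyl)carbonyl group.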